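Swapping bromo for methoxy on a sulfone analogue

The compounds below may be only part of what the source reports. "The series", "measured", "known", "first", "only" and "open" are said of these compounds alone.

Measured compounds:
compound 1, `COc1ccc(/C=C(/Sc2ccc(Br)cc2)C(=O)c2ccc(Br)cc2)cc1`, 25000 nM
compound 2, `O=C(/C(=C\c1ccc(Br)cc1)Sc1ccc(Br)cc1)c1ccc(Br)cc1`, 1000 nM
compound 3, `O=C(/C(=C\c1ccc(Cl)cc1Cl)S(=O)(=O)c1ccc(Br)cc1)c1ccc(Br)cc1`, 10000 nM

All three were tested in a functional assay on DU-145 cells (Homo sapiens) for inhibition, read by trypan blue exclusion, with a stated time of 96 h; a higher number here means a weaker inhibitor of growth, a lower number a stronger inhibitor of growth. Compound 2 and compound 1 differ in one place, (methoxy in place of bromo on an aromatic carbon), and this change gave a 25-fold higher number from compound 2 to compound 1 (1.40 log units; beyond the scatter). Compound 3 and compound 2 differ more broadly; how their two cores differ is not broken down here, so only their values can be compared, and compound 3 gives 10000 nM against compound 2 with 1000 nM.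

Compound 4, `COc1ccc(S(=O)(=O)/C(=C/c2ccc(Cl)cc2Cl)C(=O)c2ccc(Br)cc2)cc1`, has not been measured. It differs from compound 3 by methoxy in place of bromo on an aromatic carbon, the same change as between compound 2 and compound 1. Because the earlier step of a 25-fold higher number from compound 2 to compound 1 (1.40 log units; beyond the scatter) was large and in one direction, a weakening is expected here too, though the different core leaves its size uncertain. The step from compound 3 to compound 4 is estimated at a 6.0-fold higher number from compound 3 to compound 4 (0.78 log units; beyond the scatter). For compound 4 the expected value is 60000 nM, between 15000 nM and 250000 nM.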

Compound 4, concentration for 50% growth inhibition: 20000 nM
Estimate against measurement, compound 4: 3.0-fold (0.48 log units) above, within the range that was stated.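

In this assay, swapping 4-bromophenyl for 4-methoxyphenyl gave a 2.0-fold higher number from compound 3 to compound 4 (0.30 log units; within the scatter), a step too small to separate from the ordinary variation between repeat measurements. For the compounds shown here, the size of this swap therefore does not carry over from one core to the other, since the two steps clearly differ: the same change on two cores in this assay, a 25-fold higher number (1.40 log units; beyond the scatter) from compound 2 to compound 1 and a 2.0-fold higher number (0.30 log units; within the scatter) from compound 3 to compound 4, 13-fold (1.10 log units) apart, beyond the scatter of two such steps With only one pair on each core, this shows that the large step is not a fixed value for the swap, but it does not show which structural difference between the cores accounts for the gap.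

As far as these compounds go, whether an amine or a carboxylic acid in place of the bromo would also behave differently on the two cores remains open. So does the outcome of the methoxy swap on cores that differ from each other in only one place.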